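Expected Solubility After Replacing Piperidinyl With Chloro

The source may hold more compounds than are shown below. What is called first, only, known or untested is meant among the compounds shown, and "the series" means these compounds.

Of the compounds shown here, three have been measured in a physicochemical assay for solubility, read by HPLC, in phosphate buffer, with a stated time of 24 h, at pH 7.4; a lower number here means a less soluble compound, a higher number a more soluble compound. Compound 1 `Clc1ccc2c(NCCNc3nccc(Cl)n3)ccnc2c1` gives 900 nM in this assay. Compound 3 `Clc1ccc2c(NCCCCCCCCNc3nccc(Cl)n3)ccnc2c1`, which carries a much longer chain between the two ends, gives 90 nM. Compound 2 `Clc1ccc2c(NCCCNc3nccc(N4CCCCC4)n3)ccnc2c1` gives 250 nM. Among these three numbers compound 2 stands second highest: its nearest neighbour is compound 3, whose value is lower by a margin beyond the scatter, and its furthest is compound 1, whose value is higher, again beyond the scatter.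

Compound 4 `Clc1ccc2c(NCCCNc3nccc(Cl)n3)ccnc2c1` has not yet been measured. It differs from compound 2 in one place: chloro in place of piperidin-1-yl on an aromatic carbon. Among the measured compounds shown here, no pair of measured compounds differing in a single place is available, so the size of this change has to be judged from the three values alone. Compound 1 and compound 3 both carry chloro at the same place as compound 4, and their values sit on either side of the value of compound 2. The step of a 2.0-fold higher number from compound 2 to compound 4 (0.30 log units; within the scatter) is therefore expected to be a modest rise, probably not clearly beyond the scatter. Compound 4 is estimated at 500 nM, with a likely range from 150 nM to 1500 nM.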

Compound 4, solubility: 400 nM
Estimate against measurement, compound 4: 1.3-fold (0.10 log units) above; measured number inside the range.
By their numbers in this assay, from the lowest: compound 3; then compounds 2 and 4 (each within the scatter of the next); then compound 1.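

In this assay, among the compounds shown here, putting chloro in place of piperidin-1-yl on an aromatic carbon, next to the ring nitrogen of the six-membered aromatic ring with 2 nitrogen, gives a 1.6-fold higher number from compound 2 to compound 4 (0.20 log units; within the scatter), the first direct reading of a change at this position. The exchange is a large one on paper: piperidin-1-yl, with 6 heavy atoms, a six-membered non-aromatic ring and 1 hydrogen-bond acceptor, leaves, and chloro, with 1 heavy atom, no ring and no hydrogen-bond acceptor, enters. Even so, the numbers for the two compounds cannot be told apart in this measurement, and nothing available explains that outcome.

From the compounds shown here alone, this is a single pair with one linker, so it remains open whether the two groups would also give numbers this close on a longer chain. Going by these compounds, it is equally open how other groups at this same place would read, such as a small amine like dimethylamino, morpholin-4-yl, which keeps a six-membered ring but adds an oxygen, or a carboxylic acid.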